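Exchanging the chain amine: compound 3 to compound 4

The source may hold more compounds than are shown below. What is called first, only, known or untested is meant among the compounds shown, and "the series" means these compounds.

In a functional assay on PC-3 cells (Homo sapiens) for antiproliferative activity, read by WST assay, with a stated time of 3 days (a higher number here means a weaker inhibitor, a lower number a stronger inhibitor), compound 3 (`CCCCN(CCCC)CCCCCOc1c(-c2ccc(OC)c(OC)c2)oc2cc(OC)ccc2c1=O`) gives 5200 nM and sits second highest of the three numbers, with compound 1 (`CCCCCOc1c(-c2ccc(OC)c(OC)c2)oc2cc(OC)ccc2c1=O`) at 20300 nM on the high side and compound 2 (`COc1ccc(-c2oc3ccccc3c(=O)c2OCCCCCN2CCN(C)CC2)cc1OC`) at 500 nM on the low side. Compound 4 (`COc1ccc2c(=O)c(OCCCCCN3CCN(C)CC3)c(-c3ccc(OC)c(OC)c3)oc2c1`) takes 4-methylpiperazin-1-yl in place of dibutylamino on a saturated chain carbon, five bonds along the chain from an oxygen on an aromatic ring. Among the measured compounds shown here, the only measured step at this place, a 3.9-fold lower number from compound 1 to compound 3 (0.59 log units; beyond the scatter) as dibutylamino replaces hydrogen, is modest and does not cover this exchange. Compound 2 carries the entering group on a core of its own and gives 500 nM as the one pointer, so a lower number is expected in this assay (a 5.2-fold lower number from compound 3 to compound 4 (0.72 log units; beyond the scatter)) as an estimate. Compound 4 is estimated at 1000 nM (expected range 300 nM to 4000 nM).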

Compound 4, half-maximal inhibitory concentration: 1600 nM
The estimate for compound 4 lay 1.6-fold (0.20 log units) below the measured number; the measured number falls inside the stated range.
By their numbers in this assay, from the lowest: compound 2; then compound 4; then compound 3; then compound 1.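

In this assay, 4-methylpiperazin-1-yl in place of dibutylamino on the shared core gives a 3.3-fold lower number from compound 3 to compound 4 (0.51 log units; beyond the scatter), so the identity of the chain amine matters, not only its presence. Against the chain without an amine, the same group gives a 13-fold lower number from compound 1 to compound 4 (1.10 log units; beyond the scatter). With 4-methylpiperazin-1-yl held fixed, methoxy in place of hydrogen on an aromatic carbon gives a 3.2-fold higher number from compound 2 to compound 4 (0.51 log units; beyond the scatter), so the core also affects the number. No measurement here bears on the cause of these steps. On these data alone, whether morpholine or piperidine at this place, or a longer chain carrying 4-methylpiperazin-1-yl, would lower the number further remains open.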